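Compound 1 to compound 3: benzamido in place of methyl

A few compounds are considered here, and "the series" means these few. Any claim that something is new, unique, unknown or untested is made for them only; others in the source may bear on it.

Within the data shown here, compound 1 `Cc1cccc(Nc2nc3cnc(Nc4ccc(N5CCN(C)CC5)cc4)nc3n2C2CCCC2)c1` gives 4700 nM in a functional assay on HepG2 cells (Homo sapiens) for cytotoxicity, read by MTT assay, with a stated time of 72 h (on this read-out higher numbers stand for weaker inhibition and lower numbers for stronger inhibition), and holds the only number so far. Compound 2 `CN1CCN(c2ccc(Nc3ncc4nc(Nc5ccc(Br)cc5F)n(C5CCCC5)c4n3)cc2)CC1` reads > 5000 nM in this assay and this value is a limit, not a number. Compound 3 `CN1CCN(c2ccc(Nc3ncc4nc(Nc5cccc(NC(=O)c6ccccc6)c5)n(C5CCCC5)c4n3)cc2)CC1` is unmeasured and carries benzamido in place of methyl on an aromatic carbon, meta to a large group (benzamido in place of methyl on an aromatic carbon). Among the measured compounds shown here, the one measured step that replaces the 3-methylphenyl group (an at least 1.0-fold higher number from compound 1 to compound 2 (0.02 log units; that floor lies within the scatter)) offers no size to carry over. The expected step is no larger than the scatter in this assay (a 1.6-fold lower number from compound 1 to compound 3 (0.19 log units; within the scatter)). The estimate for compound 3 is 3000 nM with an expected range of 800 nM to 10000 nM as a working guide.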

Compound 3, half-maximal inhibitory concentration: 2600 nM
Estimate against measurement, compound 3: 1.2-fold (0.06 log units) above; the range from low to high includes it.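

Benzamido on an aromatic carbon, meta to a large group, gives a 1.8-fold lower number from compound 1 to compound 3 (0.26 log units; within the scatter) in this assay, so this place takes 9 heavy atoms in place of 1 without a step beyond the scatter. Compound 3 thus supplies a measured number for a large group here. Compound 2 remains a limit, not a number, so its step sets no size beside this one: the limit of > 5000 nM in this assay, at which 1 of the 3 values shown sits.

Going by these compounds, whether the benzene ring or the amide carries any of this stays open. So does how an amine or a carboxylic acid at this place would read.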